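Quinazoline sulfonamide series: cytotoxicity notes toward compound 4

This account rests on a few compounds, and the source may have more. Where it says the series, first, only, none or still open, it means among the compounds named here.

compound 1 `COc1cc2nc(Cl)nc(NS(=O)(=O)c3cccc(C(F)(F)F)c3)c2cc1OC`: 36.4 ug/mL in a functional assay on THP-1 cells (Homo sapiens) for cytotoxicity, read by MTT assay, with a stated time of 24 h; a lower number here means a stronger inhibitor, a higher number a weaker inhibitor
compound 2 `COc1cc2nc(N3CCCC3)nc(NS(=O)(=O)c3ccc(C)cc3)c2cc1OC`: 7.06 ug/mL
compound 3 `COc1ccc(S(=O)(=O)Nc2nc(Cl)nc3cc(OC)c(OC)cc23)cc1C`: 79 ug/mL

Among the three measured compounds, compound 3 gives the highest number; compound 1 stands nearest, compound 2 furthest, and both gaps lie beyond the scatter. Compound 4 `COc1cc2nc(Cl)nc(NS(C)(=O)=O)c2cc1OC` is not yet measured. It differs from compound 3 by methyl in place of 4-methoxy-3-methylphenyl on a sulfonyl sulfur. For the measured compounds named here, no two measured compounds differ in a single place, so no measured step supports the estimate. With compound 3 already the highest of the set, the expected step in this assay is toward a higher number, beyond the scatter. The expected step is a 1.4-fold higher number from compound 3 to compound 4 (0.14 log units; within the scatter). Compound 4 is expected to give 110 ug/mL, ranging from 50 ug/mL to 250 ug/mL, with a fair chance that only a limit is reported.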

Compound 4, half-maximal inhibitory concentration: 99.7 ug/mL
For compound 4 the middle estimate is 1.1-fold (0.04 log units) above the measured one, within the range that was stated.
By their numbers in this assay, from the lowest: compound 2; then compound 1; then compounds 3 and 4 (each within the scatter of the next).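

In this assay, for the compounds shown here, the replacement of 4-methoxy-3-methylphenyl by methyl on a sulfonyl sulfur gives a 1.3-fold higher number from compound 3 to compound 4 (0.10 log units; within the scatter) and provides the first comparison that differs in one place. With the aromatic ring gone from this place, the two compounds cannot be told apart in this read-out, so for this pair the ring is not needed for the number obtained. Nothing available explains why the two compounds read alike.

On these data alone, what a butyl chain, an amine or a carboxylic acid on the sulfonyl sulfur would give in this assay remains open.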